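Replacing the Guanidine-Type Group of Compound 2 with an Ester Chain

This account rests on a few compounds, and the source may have more. Where it says the series, first, only, none or still open, it means among the compounds named here.

Of the compounds shown here, three sharing a core have been measured in a functional assay (aorta) with Rattus norvegicus as the target; a lower number here means that less compound is needed, a higher number that more compound is needed for the effect. Compound 1 `CNC(=N)Nc1nc(-c2ccc(OC)cc2)c(-c2ccc(OC)cc2)s1` gives 1.2 uM. Compound 2 `COc1ccc(-c2nc(/N=C(\N)NC(C)C)sc2-c2ccc(OC)cc2)cc1` gives 9.1 uM, and compound 3 `CNC(=O)NCc1nc(-c2ccc(OC)cc2)c(-c2ccc(OC)cc2)s1` gives 15 uM. Among these three numbers compound 2 stands second highest: its nearest neighbour is compound 3, within the scatter, while the step of a 7.6-fold higher number from compound 1 to compound 2 (0.88 log units; beyond the scatter) lies beyond it.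

Compound 4 `CCOC(=O)/C=C/c1nc(-c2ccc(OC)cc2)c(-c2ccc(OC)cc2)s1` is not yet measured. It differs from compound 2 in that (a group of 7 heavy atoms (5 carbon, 2 oxygen; no ring) in place of a group of 7 heavy atoms (4 carbon, 3 nitrogen; no ring), on an aromatic carbon). The group that leaves carries 2 hydrogen-bond donors and the group that enters carries none, so compound 4 is the only one of the four without a donor at this position.

Among the measured compounds shown here, two measured steps concern this same position: a 7.6-fold higher number from compound 1 to compound 2 (0.88 log units; beyond the scatter) and a 13-fold higher number from compound 1 to compound 3 (1.10 log units; beyond the scatter), both beyond the scatter, while a 1.6-fold higher number from compound 2 to compound 3 (0.22 log units; within the scatter) is within it. Changes here have therefore moved the number in this assay by modest to large amounts. For the measured compounds named here, since every measured compound still has a donor at this place, no step shows what its complete loss does. The step from compound 2 is expected to be a 1.6-fold higher number from compound 2 to compound 4 (0.22 log units; within the scatter). For compound 4 the expected value in this assay is 15 uM, with a range from 4 uM to 60 uM.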

Compound 4, concentration for half-maximal effect: > 100 uM
Compound 4 ended at the assay's limit; the forecaster's own chance of this, stated with the estimate: 10%; at least 6.6-fold (0.82 log units) between middle value and limit.
By their numbers in this assay, from the lowest: compound 1; then compounds 2 and 3 (each within the scatter of the next). At a limit, above all of these: compound 4.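

Compound 4 gives > 100 uM in this assay, which is a limit of the assay and not a number, and no other compound shown sits at it: the limit of > 100 uM in this assay, at which 1 of the 4 values shown sits.

Read against that limit, the steps are an at least 10-fold higher number from compound 2 to compound 4 (1.04 log units; beyond the scatter), an at least 6.6-fold higher number from compound 3 to compound 4 (0.82 log units; beyond the scatter) and an at least 83-fold higher number from compound 1 to compound 4 (1.92 log units; beyond the scatter), all beyond the scatter. The earlier compounds shown here showed only that this position responds to changes among groups carrying hydrogen-bond donors, whereas compound 4 shows that 2-(ethoxycarbonyl)ethenyl, which carries no hydrogen-bond donors, takes the number in this assay past every measured value, so that the position does not accept any group of this size equally.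

The change from compound 2 to compound 4 removes the hydrogen-bond donors and also brings in a second double bond and a different set of hydrogen-bond acceptors, so these four compounds cannot say which of these differences goes with the step. Going by these compounds, a simple amine at this position, a carboxylic acid in place of the ethyl ester, or a saturated chain ending in the same ester would be needed to separate them, and the true value of compound 4 remains unknown beyond its limit.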